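A bulkier aryl urea tail on a dimethoxy-substituted core

This account rests on a few compounds, and the source may have more. Where it says the series, first, only, none or still open, it means among the compounds named here.

Compound 1 `COc1ccccc1NC(=O)Nc1cccc(CNc2ncnc3ccccc23)c1` and compound 2 `O=C(Nc1cccc(CNc2ncnc3ccccc23)c1)Nc1ccccc1F` in a functional assay on MGC-803 cells (Homo sapiens) for antiproliferative activity, read by MTT assay (a higher number here means a weaker inhibitor, a lower number a stronger inhibitor), give 39300 nM for compound 1 and 33400 nM for compound 2, and the step of a 1.2-fold lower number from compound 1 to compound 2 (0.07 log units; within the scatter) lies within the scatter. Compound 3 `COc1cc2ncnc(NCc3cccc(NC(=O)Nc4ccccc4C)c3)c2cc1OC` stands at the limit of > 50000 nM in this assay, at which 1 of the 3 values shown sits; its entry > 50000 nM in this assay is a limit, not a number. Compound 4 `COc1cc2ncnc(NCc3cccc(NC(=O)Nc4ccc(C(C)(C)C)cc4)c3)c2cc1OC` differs from compound 3 in one place: 4-(tert-butyl)phenyl in place of 2-methylphenyl on an amide-type nitrogen. Among the measured compounds shown here, no measured step covers this change, and the single step that exists, a fluoro for methoxy swap, moved nothing beyond the scatter. With every value weak or at the limit, compound 4 is expected to stay weak, the estimated step being a number no higher from compound 3 to compound 4 (the limit leaves the size open). Compound 4 is estimated at 50000 nM, with a range from 15000 nM to 160000 nM.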

Compound 4, half-maximal inhibitory concentration: 6790 nM
Estimate against measurement, compound 4: 7.4-fold (0.87 log units) above; the whole stated range lies above it.
By their numbers in this assay, from the lowest: compound 4; then compounds 2 and 1 (each within the scatter of the next). At a limit, above all of these: compound 3.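

On the amide-type nitrogen, replacing 2-methylphenyl with 4-(tert-butyl)phenyl gives the first change shown to exceed the scatter in this assay, with an at least 7.3-fold lower number from compound 3 to compound 4 (0.86 log units; beyond the scatter). The aryl group on this nitrogen can therefore shift antiproliferative activity on the dimethoxy-substituted core. The entry for compound 3 is a limit, not a number, so the true size of the step stays open: the limit of > 50000 nM in this assay, at which 1 of the 4 values shown sits.

From the compounds shown here alone, whether an amine or a carboxylic acid on that phenyl ring would keep the lower number remains open. So does whether 4-(tert-butyl)phenyl would act alike on the core of compound 1.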